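From methylcarbamoyl to pyridin-2-yl, with only limits to go on

This account rests on a few compounds, and the source may have more. Where it says the series, first, only, none or still open, it means among the compounds named here.

In an ADME assay on HEK293 cells (Homo sapiens) for cytotoxicity, read by ATP content, with a stated time of 6 h (a lower number here means that less compound is tolerated, a higher number that more compound is tolerated), compound 2 (`CCCCNc1nc(N)nc2ccn(CC(=O)NC)c12`) gives > 24000 nM as a limit and not a number. Compound 1 (`CCCCNc1nc(N)nc2ccn(Cc3ccccc3)c12`) gives > 24000 nM as a limit too. Compound 3 (`CCCCNc1nc(N)nc2ccn(Cc3ccsc3)c12`) also gives > 24000 nM as a limit.

Compound 4 (`CCCCNc1nc(N)nc2ccn(Cc3ccccn3)c12`) differs from compound 2 by carrying pyridin-2-yl in place of methylcarbamoyl on a saturated chain carbon bound to an aromatic nitrogen. Three measured steps change the group at this same place: (a step that the two limits leave unreadable from compound 1 to compound 2), (a step that the two limits leave unreadable from compound 1 to compound 3) and (a step that the two limits leave unreadable from compound 2 to compound 3). None of them has a size that can be read. What the series offers is a shared ceiling (the limit of > 24000 nM in this assay, at which 3 of the 3 values shown sit) reached with phenyl, thiophen-3-yl and methylcarbamoyl alike.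

On that basis, no step beyond the usual scatter is expected (a step that the limit leaves unreadable from compound 2 to compound 4) in this assay, and no direction can be assigned. For compound 4 the estimated value is 30000 nM with an expected range from 15000 nM to 60000 nM and a report as a limit is the likelier outcome.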

Compound 4, half-maximal cytotoxic concentration: > 24000 nM
Compound 4 gave a limit, no number (the forecaster's own chance of this, stated with the estimate: 85%); the middle value lies beyond the limit too.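

No step between compound 4 and compound 1, compound 2 or compound 3 can be read in this assay, as all four compounds stand at a shared limit: the limit of > 24000 nM in this assay, at which 4 of the 4 values shown sit.

The compounds shown leave open at what concentration any of the four becomes cytotoxic, and whether exchanging these groups changes that concentration at all.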